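Trimming the alkoxy group to methoxy: compound 4

A few compounds are considered here, and "the series" means these few. Any claim that something is new, unique, unknown or untested is made for them only; others in the source may bear on it.

Compound 3 `CCC(CC)Oc1cc([N+](=O)[O-])ccc1N(C)S(C)(=O)=O` stands at the low end of the three numbers in an assay on SK-BR-3 cells for inhibition of Aromatase (Homo sapiens) (on this read-out higher numbers stand for weaker inhibition and lower numbers for stronger inhibition), with 230 nM, and its distance to compound 2 lies within the scatter. Compound 1 `CN(c1ccc([N+](=O)[O-])cc1OCC1CCCCC1)S(C)(=O)=O` gives 960 nM and compound 2 `CN(c1ccc([N+](=O)[O-])cc1OC1CCCC1)S(C)(=O)=O` gives 440 nM. Among the measured compounds shown here, the measured steps read a 2.2-fold lower number from compound 1 to compound 2 (0.34 log units; beyond the scatter), a 4.2-fold lower number from compound 1 to compound 3 (0.62 log units; beyond the scatter) and a 1.9-fold lower number from compound 2 to compound 3 (0.28 log units; within the scatter): so far the groups with fewer heavy atoms on the oxygen have gone with lower numbers, with no compound against this. Compound 4 `COc1cc([N+](=O)[O-])ccc1N(C)S(C)(=O)=O` carries the change (methyl in place of pentan-3-yl on an oxygen on an aromatic ring), a far larger cut than any measured step covers, so those steps bear on it only loosely. A reversal of the run is expected, a 2.2-fold higher number from compound 3 to compound 4 (0.34 log units; beyond the scatter). Compound 4 is estimated at 500 nM, between 120 nM and 2500 nM.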

Compound 4, half-maximal inhibitory concentration: > 25000 nM
Compound 4: no number, only a limit (the forecaster's own chance of this, stated with the estimate: 5%); middle value at least 50-fold (1.69 log units) from the limit.
By their numbers in this assay, from the lowest: compounds 3 and 2 (each within the scatter of the next); then compound 1. At a limit, above all of these: compound 4.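

In this assay compound 4 gives > 25000 nM, a limit of the assay and not a number. At this oxygen, methoxy breaks the run in which smaller groups went with lower numbers: the steps read an at least 100-fold higher number from compound 3 to compound 4 (2.03 log units; beyond the scatter), an at least 56-fold higher number from compound 2 to compound 4 (1.75 log units; beyond the scatter) and an at least 26-fold higher number from compound 1 to compound 4 (1.41 log units; beyond the scatter). All three are far larger than any step among compound 1, compound 2 and compound 3.

Where the numbers turn between methyl and pentan-3-yl stays open, since ethyl, isopropyl and a propyl chain on this oxygen are not among the compounds shown. From the compounds shown here alone, the actual number of compound 4 also stays open.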